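Replacing Propargyl With Trifluoromethylbenzyl in a Cytotoxicity Series

A few compounds are considered here, and "the series" means these few. Any claim that something is new, unique, unknown or untested is made for them only; others in the source may bear on it.

Compound 1 `CCN(CC)c1ccc2cc(C(=O)c3ccc(N4CCN(C(=O)CN5CCN(S(=O)(=O)c6ccc(C#N)cc6)CC5)CC4)cc3)oc2c1` gives 44100 nM in an ADME assay on L02 cells (Homo sapiens) for cytotoxicity, read by MTT assay, with a stated time of 48 h; on this read-out higher numbers stand for weaker inhibition and lower numbers for stronger inhibition.
Compound 2 `C#CCN1CCN(CC(=O)N2CCN(c3ccc(C(=O)c4cc5ccc(N(CC)CC)cc5o4)cc3)CC2)CC1` gives > 100000 nM in this assay, which is a limit of the assay and not a number.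

Compound 2 therefore sits at the limit, with the step of an at least 2.2-fold higher number from compound 1 to compound 2 (0.35 log units; beyond the scatter) beyond the scatter. Compound 3 `CCN(CC)c1ccc2cc(C(=O)c3ccc(N4CCN(C(=O)CN5CCN(Cc6ccc(C(F)(F)F)cc6)CC5)CC4)cc3)oc2c1` differs from compound 2 by 4-(trifluoromethyl)phenyl in place of ethynyl on a saturated chain carbon bound to an amine nitrogen in a ring. Going by the values given here, the only measured step that bears on this is an at least 2.2-fold higher number from compound 1 to compound 2 (0.35 log units; beyond the scatter), where an aromatic group gave way to propargyl and the number rose; compound 3 brings an aromatic ring back. Compound 3 is thus expected to land near compound 1, at an estimated 50000 nM (range 15000 nM to 150000 nM), an expected step of an at least 2.0-fold lower number from compound 2 to compound 3 (0.30 log units; that floor lies within the scatter).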

Compound 3, half-maximal inhibitory concentration: 6540 nM
Compound 3: the middle estimate sits 7.6-fold (0.88 log units) above what was measured; measured number outside the range, below it.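

On the amine nitrogen in the ring, the group carried there strongly shapes the result in this assay: 4-(trifluoromethyl)benzyl in place of propargyl gives an at least 15-fold lower number from compound 2 to compound 3 (1.18 log units; beyond the scatter). An aromatic ring alone does not settle the number, as 4-(trifluoromethyl)benzyl in place of (4-cyanophenyl)sulfonyl gives a 6.7-fold lower number from compound 1 to compound 3 (0.83 log units; beyond the scatter). The true size of the first step stays unknown, as compound 2 has a limit of the assay and not a number: the limit of > 100000 nM in this assay, at which 1 of the 3 values shown sits.

The compounds shown cannot separate the contribution of the ring from that of the trifluoromethyl group. A plain benzyl group on this nitrogen would speak to that.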